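A few compounds are considered here, and "the series" means these few. Any claim that something is new, unique, unknown or untested is made for them only; others in the source may bear on it.

Compound 2 `COc1cc(Oc2cccc(Nc3ccccc3)c2)cc(OC)c1CNC(C)C` gives in a functional assay on HCT-15 cells (Homo sapiens) for inhibition, read by MTT assay, with a stated time of 72 h (on this read-out higher numbers stand for weaker inhibition and lower numbers for stronger inhibition), only a limit, > 20000 nM. It shares its core with compound 1 `COc1cc(Oc2cccc(Nc3ccccc3)c2)cc(OC)c1CNCc1ccc(Br)cc1`, which in this assay gives 5410 nM. The step of an at least 3.6-fold higher number from compound 1 to compound 2 (0.56 log units; beyond the scatter) shows that trading the 4-bromobenzyl on the amine nitrogen for isopropyl weakens inhibition, and compound 2 sits at the limit of > 20000 nM in this assay, at which 1 of the 3 values shown sits. Compound 4 `COc1cc(Oc2cccc(Nc3ccccc3)c2)cc(OC)c1CN[C@H](C)c1ccccc1` is not yet measured; it differs from compound 2 by 1-phenylethyl in place of isopropyl on an amine nitrogen. This change brings an aromatic ring back to the amine nitrogen, much like reversing the step from compound 1. Compound 3 `COc1ccc([C@@H](C)NCc2c(OC)cc(Oc3cccc(Nc4ccccc4)c3)c(OC)c2OC)cc1`, which carries a closely related group on its amine nitrogen but a different core, gives 4690 nM in this assay. Compound 4 is therefore expected to show an estimated at least 3.6-fold lower number from compound 2 to compound 4 (0.56 log units; beyond the scatter), landing near 5500 nM with a range from 2000 nM to 20000 nM.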

Compound 4, half-maximal inhibitory concentration: 7550 nM
Estimate against measurement, compound 4: 1.4-fold (0.14 log units) below; the range from low to high includes it.
By their numbers in this assay, from the lowest: compounds 3, 1 and 4 (each within the scatter of the next). At a limit, above all of these: compound 2.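

Putting 1-phenylethyl in place of isopropyl on the amine nitrogen gives an at least 2.6-fold lower number from compound 2 to compound 4 (0.42 log units; beyond the scatter) in this assay. The reading for compound 2 is only a limit: the limit of > 20000 nM in this assay, at which 1 of the 4 values shown sits. The ring need not come as 4-bromobenzyl, since the swap to 1-phenylethyl gives a 1.4-fold higher number from compound 1 to compound 4 (0.14 log units; within the scatter), so an aromatic ring without bromine serves about as well here. Still open, on these data alone, is whether a cyclohexyl ring or a longer chain on the amine nitrogen would do the same, so the aromatic ring itself may or may not be what counts.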